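The compounds below may be only part of what the source reports. "The series", "measured", "known", "first", "only" and "open" are said of these compounds alone.

Measured so far in an assay on isolated protein for inhibition of malate dehydrogenase, mitochondrial (Sus scrofa), with stated times of 45 min and 30 min; a lower number here means a stronger inhibitor, a higher number a weaker inhibitor:
Compound 1, `O=S(=O)(Nc1ccc(-c2nc3ccccc3o2)cc1)c1cccc(F)c1`, gives > 63000 nM, a limit of this assay rather than a number.
Compound 2, `O=S(=O)(Nc1ccc(-c2nc3ccccc3o2)cc1)c1ccccc1F`, gives > 63000 nM, again a limit.
Compound 3, `O=S(=O)(Nc1ccc(-c2nc3ccccc3o2)cc1)c1cccs1`, gives > 63000 nM, also a limit.

All three values sit at the same limit, as the limit of > 63000 nM in this assay, at which 3 of the 3 values shown sit, records, so compound 3 stands at a limit and nowhere else on the numbers shown. For that reason the steps a step that the two limits leave unreadable from compound 1 to compound 2, a step that the two limits leave unreadable from compound 1 to compound 3 and a step that the two limits leave unreadable from compound 2 to compound 3 cannot be read in size or direction. Compound 4, `CCc1ccc(S(=O)(=O)Nc2ccc(-c3nc4ccccc4o3)cc2)cc1`, differs from compound 3 in one place: 4-ethylphenyl in place of thiophen-2-yl on a sulfonyl sulfur. Among the compounds with values here, none of the measured steps bears on this change in a readable way, so no direction beyond the scatter can be drawn from them. Compound 4 is therefore expected to give 60000 nM, estimated between 15000 nM and 200000 nM. The expected step is an at least 1.0-fold lower number from compound 3 to compound 4 (0.02 log units; that floor lies within the scatter).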

Compound 4, half-maximal inhibitory concentration: > 63000 nM
Compound 4: no number, only a limit (the forecaster's own chance of this, stated with the estimate: 65%); middle value at least 1.0-fold (0.02 log units) away from the limit.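

Within the data shown here, compound 4 sits at the same limit as compound 1, compound 2 and compound 3, so no step among them can be read in size or direction: the limit of > 63000 nM in this assay, at which 4 of the 4 values shown sit. On these data alone, whether any group on the sulfonyl sulfur gives a real number in this assay stays open.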